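Working notes: from compound 1 to compound 4

The source may report more compounds than this note shows. Statements on the series, on what has been measured and on what is new or still open speak of the compounds shown alone.

In a physicochemical assay for solubility, read by LC-MS, in phosphate buffer, with a stated time of 24 h, at pH 7.4 (a higher number here means a more soluble compound, a lower number a less soluble compound), compound 1 (`Cc1ncc(-c2cnc(NCc3c(F)ccc4c3CCO4)c3cn[nH]c(=O)c23)n1C`) gives 15000 nM and lies within the scatter of compound 3 (`O=C(Nc1cnc(NCc2c(F)ccc3c2CCO3)n2cnnc12)c1cccnc1`) at 12000 nM. Compound 2 (`CN(c1ccn(C)n1)c1cnc(NCc2c(F)ccc3c2CCO3)n2cnnc12`) gives 130000 nM as the highest of the three numbers, beyond the scatter from both others.

Compound 4 (`CNC(=O)c1ccc(-c2cnc(NCc3c(F)ccc4c3CCO4)c3cn[nH]c(=O)c23)c(C)n1`) keeps the core of compound 1 and has 2-methyl-6-(methylcarbamoyl)pyridin-3-yl in place of 1,2-dimethyl-1H-imidazol-5-yl on an aromatic carbon. Among the compounds with values here, no measured step makes this exchange on that core. Within the data shown here, the only measured step is an 11-fold lower number from compound 2 to compound 3 (1.03 log units; beyond the scatter) on a different core, where ((pyridin-3-yl)carbonyl)amino enters. It is large, but it bears only loosely on this change, so it suggests a direction more than a size. A smaller step of the same direction is therefore expected, and the estimate in this assay is a 2.5-fold lower number from compound 1 to compound 4 (0.40 log units; beyond the scatter) with wide uncertainty. Compound 4 is expected at 6000 nM (estimated range 1500 nM to 20000 nM).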

Compound 4, solubility: 19000 nM
Compound 4: the middle estimate sits 3.2-fold (0.50 log units) below what was measured; the range from low to high includes it.
By their numbers in this assay, from the lowest: compounds 3, 1 and 4 (each within the scatter of the next); then compound 2.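

On the core of compound 1, at the aromatic carbon para to a large group, 2-methyl-6-(methylcarbamoyl)pyridin-3-yl in place of 1,2-dimethyl-1H-imidazol-5-yl gives a 1.3-fold higher number from compound 1 to compound 4 (0.10 log units; within the scatter) in this assay. Within the data shown here, this is the first step read on this core, and it shows that this exchange of a five-membered aromatic ring for a larger six-membered one leaves the number within the scatter, unlike the large step seen on the other core with a different change. No measurement available gives a reason for this result.

The step changes the ring and its substituents together, so the separate contributions of the methyl and the methylcarbamoyl remain unresolved. Also open, going by these compounds, is how this assay responds at this position to a carboxylic acid or a primary amine in place of the methylcarbamoyl.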